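The source may hold more compounds than are shown below. What is called first, only, known or untested is meant among the compounds shown, and "the series" means these compounds.

Of the compounds shown here, three built on a shared core have been tested in an ADME assay on MT4 cells (Homo sapiens) for cytotoxicity, read by MTT assay; on this read-out lower numbers stand for higher toxicity in this test and higher numbers for lower toxicity in this test. Compound 3 `O=C(CSc1nncnc1-c1cccc2ccccc12)Nc1ccc([N+](=O)[O-])cc1Cl` gives 150000 nM, the higher of the two numbers found so far; compound 2 `COC(=O)c1ccc(NC(=O)CSc2nncnc2-c2ccccc2Cl)c(Br)c1` gives 59000 nM, and the two values lie more than the usual scatter apart. Compound 1 `O=C(CSc1nncnc1-c1ccccc1Cl)N1CCc2ccccc2C1` reaches only a limit of this assay, >= 38000 nM, as shown by the limit of >= 38000 nM in this assay, at which 1 of the 3 values shown sits. Compound 4 `O=C(CSc1nncnc1-c1cccc2ccccc12)Nc1ccccc1[N+](=O)[O-]` has not yet been measured; it differs from compound 3 by 2-nitrophenyl in place of 2-chloro-4-nitrophenyl on an amide-type nitrogen. For the measured compounds named here, no step between measured compounds traces a change of this kind, so no size can be read from the data. Compound 4 is expected to stay close to compound 3 in this assay, with an estimated step of a 1.3-fold lower number from compound 3 to compound 4 (0.10 log units; within the scatter). Compound 4 is therefore estimated at 120000 nM, between 50000 nM and 250000 nM.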

Compound 4, half-maximal cytotoxic concentration: 142000 nM
Compound 4: middle estimate off by 1.2-fold (0.07 log units), on the low side; low and high end bracket the measured number.
By their numbers in this assay, from the lowest: compound 2; then compounds 4 and 3 (each within the scatter of the next).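

Placing 2-nitrophenyl instead of 2-chloro-4-nitrophenyl on the amide-type nitrogen gives a 1.1-fold lower number from compound 3 to compound 4 (0.02 log units; within the scatter) in this assay and is the first step that can be read at this place. This exchange, which takes away the chlorine and shifts the nitro group, leaves the read-out within the scatter. Nothing measured here bears on why this is so.

The compounds shown leave open whether an amine or a carboxylic acid in place of the nitro group would stay as close. They also leave open whether this exchange would give a similar step on the 2-chlorophenyl compounds.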